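The compounds below may be only part of what the source reports. "The series", "measured", "known", "first", "only" and "open" are said of these compounds alone.

In a functional assay on HCT-116 cells (Homo sapiens) for inhibition, read by MTT assay, with a stated time of 72 h (on this read-out lower numbers stand for stronger inhibition of growth and higher numbers for weaker inhibition of growth), compound 1 `CN1CCN(C(=O)/C=C/c2ccncc2-c2ccc3ccccc3c2)CC1` gives > 30000 nM, which is a limit of the assay and not a number. Among the compounds with values here, compound 2 `CNC(=O)/C=C/c1ccncc1-c1ccc2ccccc2c1` gives 6550 nM, the only true number so far. Within the data shown here, the sole measured step, an at least 4.5-fold lower number from compound 1 to compound 2 (0.66 log units; beyond the scatter), has methylamino in place of 4-methylpiperazin-1-yl on a carbonyl carbon. It bears only loosely on compound 3 `NNC(=O)CCc1ccncc1-c1ccc2ccccc2c1`, which has 2-(aminocarbamoyl)ethyl in place of 2-(methylcarbamoyl)ethenyl on an aromatic carbon. That step gives no direction here, so the expectation rests on compound 2 at 6550 nM, with no shift beyond the scatter expected in this assay. The expected step is a 1.2-fold higher number from compound 2 to compound 3 (0.09 log units; within the scatter). For compound 3 the estimate is 8000 nM, with an expected range of 2000 nM to 30000 nM.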

Compound 3, concentration for 50% growth inhibition: > 30000 nM
Compound 3 was reported as a limit; the forecaster's own chance of this, stated with the estimate: 20%; middle value at least 3.7-fold (0.57 log units) away from the limit.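

At this position, on an aromatic carbon of the six-membered aromatic ring, 2-(aminocarbamoyl)ethyl in place of 2-(methylcarbamoyl)ethenyl gives an at least 4.5-fold higher number from compound 2 to compound 3 (0.66 log units; beyond the scatter). The read-out in this assay therefore responds to a change in the whole chain, and not only to the group on the carbonyl carbon. The value of compound 3 is a limit and not a number, so the true size of this step stays unknown: the limit of > 30000 nM in this assay, at which 2 of the 3 values shown sit.

The step combines two changes, in the chain and in the group on the carbonyl. As far as these compounds go, whether 2-(methylcarbamoyl)ethyl or 2-(aminocarbamoyl)ethenyl would stay near compound 2 remains open, and so does the effect of a carboxylic acid at the chain end.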